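The source may hold more compounds than are shown below. What is called first, only, known or untested is meant among the compounds shown, and "the series" means these compounds.

Measured compounds in a functional assay on SH-SY5Y cells (Homo sapiens) for cytotoxicity, read by MTT assay, with a stated time of 72 h; on this read-out lower numbers stand for stronger inhibition and higher numbers for weaker inhibition:
compound 1 `O=C1c2c[n+]([O-])c3ccccc3c2C(=O)c2c1c1ccccc1n2Cc1cn([C@@H]2C[C@H](O)[C@@H](CO)O2)nn1` gives 150 nM
compound 2 `CCCCN1CCN(CCCCn2c3c(c4ccccc42)C(=O)c2c[n+]([O-])c4ccccc4c2C3=O)CC1` gives 6100 nM
compound 3 `O=C1c2c[n+]([O-])c3ccccc3c2C(=O)c2c1c1ccccc1n2Cc1cn([C@@H]2O[C@H](CO)[C@@H](O)[C@H](O)[C@H]2O)nn1` gives 880 nM

Compound 2 stands at the highest number of the three, its nearest neighbour being compound 3 and its furthest compound 1, both separations lying beyond the scatter. Going by the values given here, the only step between measured compounds that differ in one place is a 5.9-fold higher number from compound 1 to compound 3 (0.77 log units; beyond the scatter); it concerns the group on the aromatic nitrogen of the shared core and tells nothing about the chain-borne substituent that distinguishes compound 2.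

Compound 4 `O=C1c2c[n+]([O-])c3ccccc3c2C(=O)c2c1c1ccccc1n2CCCN1CCC(O)CC1` is the next compound for this assay. Relative to compound 2 it carries 4-hydroxypiperidin-1-yl in place of (4-butylpiperazin-1-yl)methyl on a saturated chain carbon, three bonds along the chain from an aromatic nitrogen. No measured pair addresses an exchange of this kind, so the size and direction of the step cannot be anchored on the shown numbers; the expectation is therefore centred near compound 2, with a broad range allowing a lower number toward compound 3. Compound 4 is expected to give 4000 nM in this assay, within 900 nM to 18000 nM, which means an estimated 1.5-fold lower number from compound 2 to compound 4 (0.18 log units; within the scatter).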

Compound 4, half-maximal inhibitory concentration: 130 nM
Compound 4: the middle estimate sits 31-fold (1.49 log units) above what was measured, and the stated range ends above it.
By their numbers in this assay, from the lowest: compounds 4 and 1 (each within the scatter of the next); then compound 3; then compound 2.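

In this assay, the chain on the aromatic nitrogen proves sensitive to its terminal group: on a saturated chain carbon, three bonds along the chain from an aromatic nitrogen, 4-hydroxypiperidin-1-yl in place of (4-butylpiperazin-1-yl)methyl gives a 47-fold lower number from compound 2 to compound 4 (1.67 log units; beyond the scatter), a large step. Going by these compounds alone, the earlier step concerned only the group on the triazole-free comparison of compounds 1 and 3, so this is the first reading of how the chain-borne substituent matters. The exchange changes the ring, the size of the group and the hydrogen-bond donor count together, so the step belongs to the exchange as a whole, and nothing measured here offers an explanation for it.

The compounds shown do not separate the contribution of the hydroxyl from that of the butyl group or the second ring nitrogen. A piperidine without the hydroxyl, or a morpholine, on the same chain would bear on this.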